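A few compounds are considered here, and "the series" means these few. Any claim that something is new, unique, unknown or untested is made for them only; others in the source may bear on it.

In a functional assay on RAW264.7 cells (Mus musculus) for inhibition, read by Griess assay, with stated times of 1 h and 24 h (on this read-out higher numbers stand for weaker inhibition and lower numbers for stronger inhibition), three compounds sharing one core have been measured. Compound 1 (`CC(C)CCOc1ccccc1C1CC(=O)c2ccccc2O1`) gives 39200 nM, compound 2 (`C=CCOc1ccccc1C1CC(=O)c2ccccc2O1`) gives 37800 nM, and compound 3 (`CCCCOc1ccccc1C1CC(=O)c2ccccc2O1`) gives 48700 nM. Compound 2 therefore stands level with the other two, as its gaps to them lie within the scatter.

The next compound to be tested is compound 4 (`O=C1CC(c2ccccc2OCc2ccccc2)Oc2ccccc21`). It differs from compound 2 as follows: phenyl in place of vinyl on a saturated chain carbon bound to an oxygen on an aromatic ring. In words, phenyl takes the place of vinyl on a saturated chain carbon bound to an oxygen on an aromatic ring, which turns allyloxy into benzyloxy.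

For the measured compounds named here, three measured steps bear on this change, all of them alterations to the same chain. They are a 1.0-fold lower number from compound 1 to compound 2 (0.02 log units; within the scatter), a 1.3-fold higher number from compound 2 to compound 3 (0.11 log units; within the scatter) and a 1.2-fold higher number from compound 1 to compound 3 (0.09 log units; within the scatter). Each lies within the scatter, so this assay has not yet separated these chains. None of the three steps brings in an aromatic ring, however, so the data do not test this change directly, and the range is kept wide. No shift beyond the scatter is expected, and no direction can be favoured. The expected change is a 1.0-fold higher number from compound 2 to compound 4 (0.00 log units; within the scatter). For compound 4 the estimated value is 38000 nM, with an expected range from 18000 nM to 80000 nM.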

Compound 4, half-maximal inhibitory concentration: 18900 nM
Compound 4: middle estimate off by 2.0-fold (0.30 log units), on the high side; the measured number falls inside the stated range.
By their numbers in this assay, from the lowest: compounds 4, 2, 1 and 3 (each within the scatter of the next, the first and the last beyond it).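

In this assay, for the compounds shown here, the benzyloxy chain of compound 4 is the first at this position to carry an aromatic ring, and this change gives the first steps here that pass beyond the scatter: a 2.6-fold lower number from compound 3 to compound 4 (0.41 log units; beyond the scatter) and a 2.1-fold lower number from compound 1 to compound 4 (0.32 log units; beyond the scatter) are both modest but real on this read-out. Measured against the allyl compound, the same change gives a 2.0-fold lower number from compound 2 to compound 4 (0.30 log units; within the scatter) and so stays within the scatter, which leaves compound 2 unresolved from compound 4 as well as from compound 1 and compound 3. The position is therefore not indifferent to what sits on the saturated chain carbon bound to the oxygen, since phenyl separates from the propyl and isobutyl ends, although the modest size of these steps and the exception of compound 2 limit that reading.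

The compounds shown leave open whether a pyridine ring, a chloro-substituted phenyl, a phenylethyl group or a terminal amine at this place would carry the number further in either direction. No measurement at hand accounts for the lower numbers seen with phenyl.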